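Acetyl to aryl amide on the shared anilide core

The source may report more compounds than this note shows. Statements on the series, on what has been measured and on what is new or still open speak of the compounds shown alone.

Two compounds of the series are measured in an assay on isolated protein for inhibition of Rho-associated protein kinase 2 (Homo sapiens), read by scintillation counting, radiometric assay and 33P incorporation, with a stated time of 40 min, in the presence of a further agent that is not named here; on this read-out higher numbers stand for weaker inhibition and lower numbers for stronger inhibition. Compound 1 `CC(=O)c1ccc(OCC(=O)Nc2cccc(NC(=O)c3ccc(N(C)C)cc3)c2)cc1F` gives 98 nM, and compound 2 `CC(=O)Nc1cccc(NC(=O)COc2ccc3c(=O)ccoc3c2)c1` gives 136 nM. Compound 2 holds the higher of the two numbers, yet the gap to compound 1 lies within the scatter, so no order between them can be read. Compound 3 `CCOc1ccc(C(=O)Nc2cccc(NC(=O)COc3ccc4c(=O)ccoc4c3)c2)cc1` is not yet measured. It carries 4-ethoxyphenyl in place of methyl on a carbonyl carbon. Going by the values given here, no measured pair isolates this change, so the expected step is small, leaning toward a lower number, as compound 1 with an aryl amide gives 98 nM. For compound 3 the expected step is a 1.5-fold lower number from compound 2 to compound 3 (0.18 log units; within the scatter). Compound 3 is estimated at 90 nM, with a range from 35 nM to 250 nM.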

Compound 3, half-maximal inhibitory concentration: 9 nM
Estimate against measurement, compound 3: 10-fold (1.00 log units) above; measured number outside the range, below it.
By their numbers in this assay, from the lowest: compound 3; then compounds 1 and 2 (each within the scatter of the next).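

In this assay, going by these compounds alone, 4-ethoxyphenyl in place of methyl on a carbonyl carbon gives a 15-fold lower number from compound 2 to compound 3 (1.18 log units; beyond the scatter), the first measured single-place change. This position, on a carbonyl carbon whose other neighbour is an amide-type nitrogen, therefore accepts the larger group and strongly affects the read-out. No measurement shown gives a cause for this step.

Still open, going by these compounds, is how the step divides between the aromatic ring and the ethoxy group, which a plain phenyl would separate. Also open, on these data alone, is whether a dimethylamino group or a carboxylic acid in place of ethoxy keeps the gain.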